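The source may report more compounds than this note shows. Statements on the series, on what has been measured and on what is new or still open speak of the compounds shown alone.

Measured in a physicochemical assay for solubility, with a stated time of 4 h, at pH 2.0; on this read-out lower numbers stand for lower solubility and higher numbers for higher solubility:
- compound 1 `CNC(=O)c1cc(N)c(Nc2ccc(C#N)cc2)cc1Oc1c(C)cc(CCC#N)cc1C`: 44.7 ug/mL
- compound 2 `Cc1cc(CCC#N)cc(C)c1Oc1cc(Nc2ccc(C#N)cc2)c(N)cc1C(F)(F)F`: 0.33 ug/mL
- compound 3 `Cc1cc(CCC#N)cc(C)c1Oc1cc(Nc2ccc(C#N)cc2)c(N)cc1C(N)=O`: 9.11 ug/mL

Compound 1 has the highest of these three numbers. The step to compound 4 `CNC(=O)c1cc(N)c(Nc2ccc(C#N)cc2)cc1Oc1c(C)cc(/C=C/C#N)cc1C` places 2-cyanoethenyl in place of 2-cyanoethyl on an aromatic carbon.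

The measured steps are a 140-fold lower number from compound 1 to compound 2 (2.13 log units; beyond the scatter), a 4.9-fold lower number from compound 1 to compound 3 (0.69 log units; beyond the scatter) and a 28-fold higher number from compound 2 to compound 3 (1.44 log units; beyond the scatter). All three are large or modest, but all change a different place, so none bears directly on this one. Among the compounds with values here, the data hold no direct precedent for this change, so only a modest fall in this assay is expected, and that expectation is tentative.

The estimated change is a 2.0-fold lower number from compound 1 to compound 4 (0.31 log units; beyond the scatter). For compound 4 the expected value is 22 ug/mL, with an estimated range of 7 ug/mL to 60 ug/mL.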

Compound 4, solubility: 8.63 ug/mL
The estimate for compound 4 lay 2.5-fold (0.41 log units) above the measured number; the measured number falls inside the stated range.
By their numbers in this assay, from the lowest: compound 2; then compounds 4 and 3 (each within the scatter of the next); then compound 1.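

In this assay, 2-cyanoethenyl in place of 2-cyanoethyl gives a 5.2-fold lower number from compound 1 to compound 4 (0.71 log units; beyond the scatter). Within the data shown here, this is the first sign that the chain on the aromatic carbon para to a large group affects the read-out, since the earlier steps changed only the carbamoyl or trifluoromethyl place; here the heavy-atom count stays the same, and the change adds one double bond. No measurement offered here accounts for the fall.

From the compounds shown here alone, whether a longer chain or an amine at this place would raise or lower the number remains open. So does whether 2-cyanoethenyl would produce a step of similar size on compound 2 or compound 3.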